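The source may report more compounds than this note shows. Statements on the series, on what has been measured and on what is new or still open speak of the compounds shown alone.

Measured compounds:
compound 1, `COc1ccc(CNc2cc(OC)c(OC)c(OC)c2)cc1C`, 60900 nM
compound 2, `C/C=C/C(=O)N(Cc1ccc(OC)c(C)c1)c1cc(OC)c(OC)c(OC)c1`, 23500 nM
compound 3, `COc1ccc(CN(C(=O)CN=[N+]=[N-])c2cc(OC)c(OC)c(OC)c2)cc1O`, 410 nM

All three were tested in a functional assay on HCT-116 cells (Homo sapiens) for inhibition, read by MTT assay, with a stated time of 48 h; on this read-out higher numbers stand for weaker inhibition and lower numbers for stronger inhibition. Among them compound 2 gives 23500 nM, the second highest of the three numbers; its nearest neighbour is compound 1, which gives 60900 nM, and compound 3 is furthest with 410 nM.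

The unmeasured compound 4, `C/C=C/C(=O)N(Cc1ccc(OC)cc1)c1cc(OC)c(OC)c(OC)c1`, differs from compound 2 in one place: hydrogen in place of methyl on an aromatic carbon. The change sits on an aromatic carbon of a six-membered aromatic ring of carbon only, ortho to a methoxy group, so that 4-methoxy-3-methylphenyl becomes 4-methoxyphenyl.

Among the measured compounds shown here, the only measured step, a 2.6-fold lower number from compound 1 to compound 2 (0.41 log units; beyond the scatter), concerns the nitrogen, not this ring, and compound 3 differs from compound 2 in several places at once. For the measured compounds named here, no measured step therefore speaks to the removal of the methyl, and the expectation in this assay is a step within the scatter, in no particular direction: a 1.1-fold higher number from compound 2 to compound 4 (0.03 log units; within the scatter). Compound 4 is estimated at 25000 nM, with a range from 8000 nM to 75000 nM.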

Compound 4, half-maximal inhibitory concentration: 500 nM
Beside the measured number, compound 4's estimate is 50-fold (1.70 log units) above it; measured number outside the range, below it.
By their numbers in this assay, from the lowest: compounds 3 and 4 (each within the scatter of the next); then compound 2; then compound 1.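

In this assay, the position on the aromatic carbon ortho to a methoxy group proves highly sensitive: replacing methyl with hydrogen, so that 4-methoxy-3-methylphenyl becomes 4-methoxyphenyl, gives a 47-fold lower number from compound 2 to compound 4 (1.67 log units; beyond the scatter). This large step far exceeds the modest change at the nitrogen, a 2.6-fold lower number from compound 1 to compound 2 (0.41 log units; beyond the scatter), so the loss of one carbon from the ring accounts for more of the change in inhibition than the added acyl group on the nitrogen. Nothing available explains the size of this step.

The compounds shown leave open whether a group other than hydrogen at this position, such as a fluorine, a chlorine or an ethyl, would also give a number as low as that of compound 4. They also leave open whether removing the methyl would give a similar step with hydrogen on the nitrogen, as in compound 1.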